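This account rests on a few compounds, and the source may have more. Where it says the series, first, only, none or still open, it means among the compounds named here.

Compound 1 `COc1ccc(SCc2ccc(/C=C/C(=O)Nc3ccccc3N)cc2)cc1OC`: 12.9%
Compound 2 `Nc1ccccc1NC(=O)/C=C/c1ccc(CSc2cccc(F)c2)cc1`: 7.95%
Compound 3 `COc1ccc(SCc2ccc(C(=O)Nc3ccccc3N)cc2)cc1`: 73.3%

In a functional assay on HCT-116 cells (Homo sapiens) for inhibition, read by CCK-8 assay, with a stated time of 72 h, tested at 2 uM (a lower number here means less inhibition of growth, a higher number more inhibition of growth at the concentration tested), compound 3, at 73.3%, stands highest of the three, beyond the scatter from both of the others. Compound 4 `Cc1ccc(SCc2ccc(C(=O)Nc3ccccc3N)cc2)cc1` alters it in one place: methyl in place of methoxy on an aromatic carbon. In other words, 4-methoxyphenyl becomes 4-methylphenyl. Going by the values given here, only one measured step bears on this change: a number 5 percentage points lower from compound 1 to compound 2 (within the scatter). It also swaps the group on sulfur and stays within the scatter, but that pair has a different core and low values, so it offers limited guidance. No step beyond the scatter is therefore expected in this assay, and the estimate is a number 5.3 percentage points lower from compound 3 to compound 4 (within the scatter). For compound 4 the expected value is 68%, with an estimated range of 48% to 85%.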

Compound 4, percent growth inhibition at one concentration: 74.8%
Compound 4: middle estimate off by 6.8 percentage points, on the low side; low and high end bracket the measured number.
By their numbers in this assay, from the lowest: compounds 2 and 1 (each within the scatter of the next); then compounds 3 and 4 (each within the scatter of the next).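

In this assay, replacing 4-methoxyphenyl with 4-methylphenyl gives a number 1.5 percentage points higher from compound 3 to compound 4 (within the scatter), so on this core the reading holds without the oxygen and its hydrogen-bond acceptor. The earlier step offered only a different core and a different group on sulfur, whereas this pair isolates the change at this position. No measurement shown explains why the two groups read alike. From the compounds shown here alone, whether an ethoxy group, an amine or a chlorine atom here would hold the same reading remains open, as does whether the swap would behave alike on the core of compound 1.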